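Adding a chlorine to the benzoyl group of compound 3

This account rests on a few compounds, and the source may have more. Where it says the series, first, only, none or still open, it means among the compounds named here.

The three measured compounds share one core and differ only at the carbonyl attached to the ring nitrogen. In a functional assay on NCI-H23 cells (Homo sapiens) for cytotoxicity, read by sulforhodamine B assay, with a stated time of 72 h (on this read-out higher numbers stand for weaker inhibition of growth and lower numbers for stronger inhibition of growth), compound 1 `CC(=O)N1c2ccccc2CCC1C(=O)Nc1cc(C(F)(F)F)cc(C(F)(F)F)c1` gives only a limit of > 70000 nM. Compound 2 `O=C(Nc1cc(C(F)(F)F)cc(C(F)(F)F)c1)C1CCc2ccccc2N1C(=O)c1ccc(Cl)cc1` gives 889 nM and compound 3 `O=C(Nc1cc(C(F)(F)F)cc(C(F)(F)F)c1)C1CCc2ccccc2N1C(=O)c1ccccc1` gives 2130 nM, so compound 3 stands as the higher of the two numbers, with a 2.4-fold higher number from compound 2 to compound 3 (0.38 log units; beyond the scatter). The large steps of an at least 78-fold lower number from compound 1 to compound 2 (1.89 log units; beyond the scatter) and an at least 32-fold lower number from compound 1 to compound 3 (1.51 log units; beyond the scatter) show that an aryl carbonyl is what carries activity here.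

Compound 4 `O=C(Nc1cc(C(F)(F)F)cc(C(F)(F)F)c1)C1CCc2ccccc2N1C(=O)c1cccc(Cl)c1` differs from compound 3 by chloro in place of hydrogen on an aromatic carbon. Within the data shown here, the only measured step that bears on it is a 2.4-fold higher number from compound 2 to compound 3 (0.38 log units; beyond the scatter), which was modest; it concerned a chlorine at a different ring carbon, so its size may not carry over exactly, but it points towards a lower number. For compound 4 the expected step is therefore a 1.8-fold lower number from compound 3 to compound 4 (0.25 log units; within the scatter), modest and downward. Compound 4 is thus estimated at 1200 nM, within a range of 500 nM to 3000 nM.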

Compound 4, concentration for 50% growth inhibition: 420 nM
Estimate against measurement, compound 4: 2.9-fold (0.46 log units) above; the measured number lies below the stated range.
By their numbers in this assay, from the lowest: compound 4; then compound 2; then compound 3. At a limit, above all of these: compound 1.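

Among these compounds, the chlorine gives more than the earlier compounds could promise: a 5.1-fold lower number from compound 3 to compound 4 (0.71 log units; beyond the scatter), so chloro on this aromatic carbon of the benzoyl group has a larger effect than the chlorine of compound 2 suggested. Where the chlorine sits also matters, since the swap of 4-chlorophenyl for 3-chlorophenyl gives a 2.1-fold lower number from compound 2 to compound 4 (0.33 log units; beyond the scatter), a difference the earlier compounds could not show. Compound 1 is held at a limit, and an at least 160-fold lower number from compound 1 to compound 4 (2.22 log units; beyond the scatter) rests on it: the limit of > 70000 nM in this assay, at which 1 of the 4 values shown sits.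

The compounds shown leave open whether a fluorine, a methoxy group or an amine on the same ring carbon would match chloro. They also leave open whether a dichlorophenyl group, with chlorines at both ring carbons, would lower the number further.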